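Halogen swap on the acid analogue of a sulfonamide series

A few compounds are considered here, and "the series" means these few. Any claim that something is new, unique, unknown or untested is made for them only; others in the source may bear on it.

Measured compounds in a functional assay on K562 cells (Homo sapiens) for cytotoxicity, read by trypan blue exclusion, with a stated time of 96 h; on this read-out lower numbers stand for stronger inhibition and higher numbers for weaker inhibition:
compound 1 `COC(=O)C(Nc1cc(NS(=O)(=O)/C=C/c2c(OC)cc(OC)cc2OC)ccc1OC)c1ccc(Cl)cc1` gives 2500 nM
compound 2 `COC(=O)C(Nc1cc(NS(=O)(=O)/C=C/c2c(OC)cc(OC)cc2OC)ccc1OC)c1ccc(Br)cc1` gives 1000 nM
compound 3 `COc1cc(OC)c(/C=C/S(=O)(=O)Nc2ccc(OC)c(NC(C(=O)O)c3ccc(Cl)cc3)c2)c(OC)c1` gives 15 nM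

Two structural changes run through these three compounds. The first is bromo in place of chloro on an aromatic carbon, and it made a 2.5-fold lower number from compound 1 to compound 2 (0.40 log units; beyond the scatter). The second separates the core of compound 1 from the core of compound 3: hydrogen in place of methyl on an oxygen next to a carbonyl group, which made a 170-fold lower number from compound 1 to compound 3 (2.22 log units; beyond the scatter). Compound 2 and compound 3 differ in both places at once, and that combined difference made a 67-fold lower number from compound 2 to compound 3 (1.82 log units; beyond the scatter). Compound 3 therefore gives the lowest number of the three measured compounds.

Compound 4 `COc1cc(OC)c(/C=C/S(=O)(=O)Nc2ccc(OC)c(NC(C(=O)O)c3ccc(Br)cc3)c2)c(OC)c1` has not yet been measured in this assay. It relates to compound 3 by bromo in place of chloro on an aromatic carbon, the same change that relates compound 1 to compound 2, here made on the core of compound 3. Resting on the one earlier instance of this change, compound 4 is expected to give a step of about a 1.9-fold lower number from compound 3 to compound 4 (0.27 log units; within the scatter) in this assay, with some allowance for that single step being smaller on repetition. The estimate for compound 4 is 8 nM, expected to fall between 3 nM and 25 nM.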

Compound 4, half-maximal inhibitory concentration in the K562 assay: 75 nM
Beside the measured number, compound 4's estimate is 9.4-fold (0.97 log units) below it, and the stated range ends below it.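

In the K562 assay compound 4 gives 75 nM, and bromo in place of chloro did not carry from the core of compound 1 to the core of compound 3, with a 5.0-fold higher number from compound 3 to compound 4 (0.70 log units; beyond the scatter) running against a 2.5-fold lower number from compound 1 to compound 2 (0.40 log units; beyond the scatter): the same change on two cores in the K562 assay, a 2.5-fold lower number (0.40 log units; beyond the scatter) from compound 1 to compound 2 and a 5.0-fold higher number (0.70 log units; beyond the scatter) from compound 3 to compound 4, 13-fold (1.10 log units) apart, beyond the scatter of two such steps
The free acid in place of the methyl ester still lowered the number in the bromo pair, giving a 13-fold lower number from compound 2 to compound 4 (1.12 log units; beyond the scatter), but the size of this step depended on the halogen: the same change on two cores in the K562 assay, a 170-fold lower number (2.22 log units; beyond the scatter) from compound 1 to compound 3 and a 13-fold lower number (1.12 log units; beyond the scatter) from compound 2 to compound 4, 13-fold (1.10 log units) apart, beyond the scatter of two such steps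
With both changes together, the compounds show a 33-fold lower number from compound 1 to compound 4 (1.52 log units; beyond the scatter), so the two changes did not act independently in these four compounds, although this small set does not show why or whether the same holds on other cores.
In a physicochemical assay for solubility (on this read-out higher numbers stand for higher solubility and lower numbers for lower solubility), compound 3 gives 10000 ug/mL and compound 4 gives 10000 ug/mL, with no change at the digits printed from compound 3 to compound 4 (within the scatter).

The compounds shown leave open whether fluoro or iodo at this position would follow the halogen trend seen with the acid or with the ester. They also leave open how a primary amide in place of the carboxylic acid would respond to the same swap.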